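Methyl to ethyl on the carboxy-bearing ring carbon

The compounds below may be only part of what the source reports. "The series", "measured", "known", "first", "only" and "open" are said of these compounds alone.

Compound 2 `CCNC(=O)Nc1nc2cc(-c3cnc(N4CCC(C)(C(=O)O)CC4)nc3)cc(-c3ccccn3)c2s1` bears a methyl group on the same saturated ring carbon that carries its carboxylic acid. In an ADME assay on microsomes from liver (Mus musculus) for metabolic stability, read by LC-MS, tested at 10 uM (on this read-out higher numbers stand for fast clearance and lower numbers for slow clearance), compound 2 gives < 5.8 mL/min/kg, which is a limit of the assay rather than a measured number. Compound 1 `CCNC(=O)Nc1nc2cc(-c3cnc(N4CCC(C(=O)O)CC4)nc3)cc(-c3ccccn3)c2s1` differs from it only by a hydrogen in place of that methyl. In this assay compound 1 gives < 5.8 mL/min/kg, again a limit. The step that the two limits leave unreadable from compound 1 to compound 2 therefore has no readable size. Both values sit at the limit of < 5.8 mL/min/kg in this assay, at which 2 of the 2 values shown sit, so compound 2 stands as low as this assay can report. Compound 3 `CCNC(=O)Nc1nc2cc(-c3cnc(N4CCC(CC)(C(=O)O)CC4)nc3)cc(-c3ccccn3)c2s1` lengthens the substituent: methyl in place of hydrogen on a saturated chain carbon bound to a saturated ring carbon. Within the data shown here, the only measured step bears on this change but is unreadable, so no shift beyond the scatter is expected, and the expected step that the limit leaves unreadable from compound 2 to compound 3 is small. Compound 3 is therefore expected to show 5 mL/min/kg, with a range from 2 mL/min/kg to 13 mL/min/kg, most likely again reported as a limit.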

Compound 3, clearance: < 5.8 mL/min/kg
Compound 3: no number, only a limit (the forecaster's own chance of this, stated with the estimate: 65%); the middle value does not contradict the limit.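

In this assay compound 3 gives < 5.8 mL/min/kg, a limit and not a number, so its steps from compound 1 and compound 2 cannot be read. The compounds shown leave open whether hydrogen, methyl and ethyl at this place differ in clearance at all.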